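The source may report more compounds than this note shows. Statements on the series, on what has been measured and on what is new or still open speak of the compounds shown alone.

Measured in a functional assay on HepG2 cells (Homo sapiens) for cytotoxicity, read by MTT assay, with a stated time of 24 h; on this read-out higher numbers stand for weaker inhibition and lower numbers for stronger inhibition:
Compound 1 `COc1ccc(/C=C2\CN(C)C/C(=C\c3cccnc3)C2=O)c(OC)c1OC`: 5160 nM
Compound 2 `COc1cc(/C=C2\CN(C)C/C(=C\c3ccncc3)C2=O)cc(OC)c1OC`: 9800 nM
Compound 3 `O=C1/C(=C/c2cccnc2)CN(S(=O)(=O)c2ccc([N+](=O)[O-])cc2)C/C1=C\c1ccccc1F`: 12800 nM

Compound 3 lies within the scatter of compound 2, and its number is higher than that of compound 1, a gap beyond the scatter. Compound 4 `N#Cc1ccc(S(=O)(=O)N2C/C(=C\c3cccnc3)C(=O)/C(=C/c3ccccc3F)C2)cc1` has cyano in place of nitro on an aromatic carbon, para to a large group: cyano in place of nitro on an aromatic carbon. For the measured compounds named here, no measured pair shows this change, so no step beyond the scatter is expected in this assay, and no direction is favoured. The estimate starts from compound 3 at 12800 nM. The expected change is small, a 1.2-fold lower number from compound 3 to compound 4 (0.07 log units; within the scatter). Compound 4 is estimated at 11000 nM, with an expected range of 5000 nM to 25000 nM.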

Compound 4, half-maximal inhibitory concentration: 6600 nM
Compound 4: the middle estimate sits 1.7-fold (0.22 log units) above what was measured, and the stated range covers the measured number.
By their numbers in this assay, from the lowest: compounds 1, 4, 2 and 3 (each within the scatter of the next, the first and the last beyond it).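

In this assay, for the compounds shown here, the swap of 4-nitrophenyl to 4-cyanophenyl gives a 1.9-fold lower number from compound 3 to compound 4 (0.29 log units; within the scatter), the first pair that differs in one place. At this position, para to a large group, nitro can therefore give way to cyano without a step beyond the scatter. No measurement here offers an explanation for this result.

Open, from the compounds shown here alone, is whether an amine, a carboxylic acid or a methoxy group at this position would also stay within the scatter of compound 3. Going by these compounds, whether a bare phenyl ring would do so is equally open.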